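Replacing a Triazole Arm with a Styryl Group

The compounds below may be only part of what the source reports. "The series", "measured", "known", "first", "only" and "open" are said of these compounds alone.

Compound 1 `NC(=O)c1cn(Cc2nnc(-c3cc(S(N)(=O)=O)c(SCc4ccccc4)cc3Cl)o2)nn1` stands highest of the two numbers measured in an ADME assay on microsomes from liver (Homo sapiens) for metabolic stability, read by LC-MS, using NADPH, tested at 5 uM; on this read-out higher numbers stand for a longer-lived compound and lower numbers for a shorter-lived compound: compound 1 gives 0.435 h. Compound 2 `COc1ccc(-c2cn(Cc3nnc(-c4cc(S(N)(=O)=O)c(SCc5ccccc5)cc4Cl)o3)nn2)cc1` gives 0.215 h, and the change between them is a 2.0-fold lower number from compound 1 to compound 2 (0.31 log units; beyond the scatter). The unmeasured compound 3 `NS(=O)(=O)c1cc(-c2nnc(/C=C/c3ccccc3)o2)c(Cl)cc1SCc1ccccc1` differs from compound 1 in one place: 2-phenylethenyl in place of (4-carbamoyl-1H-1,2,3-triazol-1-yl)methyl on an aromatic carbon. Among the compounds with values here, only the step from compound 1 to compound 2 bears on this, since it alters the same arm of the shared core; there a 4-methoxyphenyl in place of a carbamoyl brought a modest drop. Compound 3 goes further and removes the whole arm, its five-membered ring included, in favour of a 2-phenylethenyl, so a drop of at least similar size is expected, estimated as a 2.2-fold lower number from compound 1 to compound 3 (0.34 log units; beyond the scatter). Compound 3 is therefore expected to give about 0.2 h in this assay, with a range from 0.08 h to 0.5 h.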

Compound 3, half-life: 0.228 h
For compound 3 the middle estimate is 1.1-fold (0.06 log units) below the measured one; the measured number falls inside the stated range.
By their numbers in this assay, from the lowest: compounds 2, 3 and 1 (each within the scatter of the next, the first and the last beyond it).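

In this assay the full exchange of the arm gives a 1.9-fold lower number from compound 1 to compound 3 (0.28 log units; within the scatter), so compound 1 and compound 3 cannot be told apart, even though the (4-carbamoyl-1H-1,2,3-triazol-1-yl)methyl group, with its hydrogen-bond donor and acceptors, gives way to a 2-phenylethenyl group with none. The earlier step, a 2.0-fold lower number from compound 1 to compound 2 (0.31 log units; beyond the scatter), changed only the end of the arm and kept the five-membered triazole ring, so it could not show that this position tolerates the loss of that ring and of every hetero atom in the arm without a step beyond the scatter. No measurement shown here explains this result. Still open, going by these compounds, is whether a group such as an amine or a carboxylic acid at this position would give a step beyond the scatter from compound 1. The same question applies to 2-phenylethyl, the same chain without its double bond.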